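The source may hold more compounds than are shown below. What is called first, only, known or untested is meant among the compounds shown, and "the series" means these compounds.

Of the compounds shown here, three built on a shared core have been measured in an ADME assay on microsomes from liver (Homo sapiens) for metabolic stability, with a stated time of 10 min; a lower number here means that less of the compound is left, a higher number that more of the compound is left. Compound 1 `CC(C)C(=O)NCCS(=O)(=O)NC(=O)c1ccc(Nc2nc(NC3(c4ccc(Cl)cc4)CC3)nc(OCC(F)(F)F)n2)cc1` gives 86%. Compound 2 `CNC(=O)NCCS(=O)(=O)NC(=O)c1ccc(Nc2nc(NC3(c4ccc(Cl)cc4)CC3)nc(OCC(F)(F)F)n2)cc1` gives 97%. Compound 3 `O=C(NS(=O)(=O)CCNC(=O)C1CC1)c1ccc(Nc2nc(NC3(c4ccc(Cl)cc4)CC3)nc(OCC(F)(F)F)n2)cc1` gives 90%, the second highest of the three numbers; its gap to compound 1 and its gap to compound 2 both lie within the scatter.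

Compound 4 `COC(=O)NCCS(=O)(=O)NC(=O)c1ccc(Nc2nc(NC3(c4ccc(Cl)cc4)CC3)nc(OCC(F)(F)F)n2)cc1` differs from compound 3 in one place: methoxy in place of cyclopropyl on a carbonyl carbon.

For the measured compounds named here, two measured steps touch the same carbonyl carbon. The step of a number 4 percentage points higher from compound 1 to compound 3 (within the scatter) and the step of a number 7 percentage points lower from compound 2 to compound 3 (within the scatter) stayed within the scatter, while the step of a number 11 percentage points higher from compound 1 to compound 2 (beyond the scatter) was the only one beyond it, and modest. Every group tried at this position has left the number high in this assay. On that basis no step beyond the scatter is expected for the change to methoxy, and compound 4 is expected at 91%, within 82% to 99%, which means an estimated step of a number 1 percentage points higher from compound 3 to compound 4 (within the scatter).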

Compound 4, percent of the compound remaining in the liver assay: 90%
Estimate against measurement, compound 4: 1 percentage points above, and the stated range covers the measured number.
By their numbers in the liver assay, from the lowest: compounds 1, 3, 4 and 2 (each within the scatter of the next, the first and the last beyond it).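

In the liver assay the methoxy group behaves like the other groups on this carbonyl carbon, with every step inside the scatter: no change at the digits printed from compound 3 to compound 4 (within the scatter), a number 7 percentage points lower from compound 2 to compound 4 (within the scatter) and a number 4 percentage points higher from compound 1 to compound 4 (within the scatter). In a physicochemical assay for permeability, using PAMPA, at pH 7.4 (a lower number here means that the compound crosses the layer more slowly, a higher number that the compound crosses the layer faster), however, compound 3 gives 1 nm/s and compound 4 gives 39 nm/s, so a change that the liver read-out does not register separates these two compounds widely in the second read-out. This position can therefore be changed with the number in the liver assay staying high, and methoxy in place of cyclopropyl goes with faster crossing of the layer: the measured apparent permeability of compound 3, 1 nm/s, and of compound 4, 39 nm/s, a 39-fold higher number (1.59 log units; beyond the scatter)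

The compounds shown do not tell whether the oxygen that enters or the ring that leaves matters more for this step. An ethoxy or a dimethylamino group on this carbonyl carbon would help to separate the two.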